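Cutting the Chain of Compound 3

The source may hold more compounds than are shown below. What is called first, only, known or untested is meant among the compounds shown, and "the series" means these compounds.

In a functional assay on PC-3 cells (Homo sapiens) for inhibition, read by MTT assay, with stated times of 18 h and 4 h (on this read-out lower numbers stand for stronger inhibition and higher numbers for weaker inhibition), compound 3 (`CCCCCCCCCCOP(=O)(O)OCCSC(=S)N1CCCC1`) gives 56100 nM, within the scatter of compound 2 (`CCCCCCCCCCOP(=O)(O)OCCSC(=S)N1CCCCCC1`) at 32900 nM. Compound 1 (`CCCCCCCCOP(=O)(O)OCCSC(=S)N1CCCC1`) yields no number, only the assay limit of > 100000 nM.

Compound 4 (`CCCCCCOP(=O)(O)OCCSC(=S)N1CCCC1`) differs from compound 3 in its chain: hydrogen in place of butyl on a saturated chain carbon, six bonds along the chain from an oxygen on an unsaturated carbon.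

The closest guide is an at least 1.7-fold lower number from compound 1 to compound 3 (0.25 log units; that floor lies within the scatter), another step that changes only the chain, though its floor lies within the scatter. The step of a 1.7-fold higher number from compound 2 to compound 3 (0.23 log units; within the scatter) concerns the ring on the thiocarbonyl carbon rather than the chain, and it also stays within the scatter. With compound 1 already at a limit with a longer chain than compound 4, a rise beyond the scatter in this assay is expected, towards weaker inhibition, and a report of only a limit is likely.

The expected change is a 2.7-fold higher number from compound 3 to compound 4 (0.43 log units; beyond the scatter). Compound 4 is estimated at 150000 nM, with an expected range from 70000 nM to 500000 nM.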

Compound 4, half-maximal inhibitory concentration: > 100000 nM
Compound 4 ended at the assay's limit; the forecaster's own chance of this, stated with the estimate: 75%; the middle value is on the limit's open side.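

Taking butyl off this saturated chain carbon, six bonds along the chain from an oxygen on an unsaturated carbon, gives an at least 1.7-fold higher number from compound 3 to compound 4 (0.25 log units; that floor lies within the scatter), so only a floor for the step can be read. In this assay compound 4 gives > 100000 nM, which is a limit of the assay and not a number. Compound 4 thus joins compound 1, and both changes that remove part of the chain of compound 3 now end without a number: the limit of > 100000 nM in this assay, at which 2 of the 4 values shown sit.

The step from compound 1 to compound 4 cannot be read, as both values are limits. Going by these compounds, whether a longer chain on the core of compound 3 would give a lower number stays open, as does how an amine or a carboxylic acid in place of butyl at this position would read.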